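A few compounds are considered here, and "the series" means these few. Any claim that something is new, unique, unknown or untested is made for them only; others in the source may bear on it.

In a functional assay on HCT-15 cells (Homo sapiens) for cytotoxicity, read by colorimetric assay and MTT assay (on this read-out lower numbers stand for stronger inhibition and higher numbers for weaker inhibition), compound 1 (`COc1cccc2cc(-c3ccccc3)c(O)nc12`) gives 10000 nM, compound 2 (`COc1cc(OC)c2cc(-c3ccccc3)c(O)nc2c1`) gives 10000 nM, and compound 3 (`COc1ccc(-c2cc3c(OC)cc(OC)cc3n(CCCC#N)c2=O)cc1`) gives 10000 nM. Compound 2 therefore stands level with the other two, and these numbers separate none of them. Compound 4 (`COc1cc(OC)c2cc(-c3ccc(O)cc3)c(O)nc2c1`) is compound 2 with hydroxy in place of hydrogen on an aromatic carbon, turning phenyl into 4-hydroxyphenyl (hydroxy in place of hydrogen on an aromatic carbon). Among the compounds with values here, no measured pair yet shows what a single change does here, so the expectation is weakly grounded. No step beyond the usual scatter is expected in this assay, in either direction. The expected step of no change at the digits printed from compound 2 to compound 4 (within the scatter) is accordingly small. For compound 4 the estimated value is 10000 nM, with an expected range from 3000 nM to 20000 nM.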

Compound 4, half-maximal inhibitory concentration: 10000 nM
Beside the measured number, compound 4's estimate shows no gap at the digits printed; the measured number falls inside the stated range.
By their numbers in this assay, from the lowest: compounds 1, 2, 3 and 4 (each within the scatter of the next).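

In this assay, within the data shown here, the first comparison of two compounds differing in one place gives no change at the digits printed from compound 2 to compound 4 (within the scatter), so swapping phenyl for 4-hydroxyphenyl, with the hydroxy para to a large group, does not separate the two compounds. This single pair shows only that adding hydroxy at this one position leaves the read-out unmoved. No measurement shown offers an explanation for this result. From the compounds shown here alone, what an amine or a carboxylic acid at the same position would do remains open, as does whether any other group there would shift the number.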